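Solubility notes: amide substitution on the shared core

The source may report more compounds than this note shows. Statements on the series, on what has been measured and on what is new or still open speak of the compounds shown alone.

Measured so far in a physicochemical assay for solubility, read by nephelometry, in phosphate buffer, measured as kinetic solubility, at pH 6.5; a lower number here means a less soluble compound, a higher number a more soluble compound:
- compound 1, `COc1ccc(-c2cc(-c3ccc(-n4cncn4)cc3)cnc2N)cn1`: 6.3 ug/mL
- compound 2, `COc1ccc(-c2cc(-c3ccc(C(N)=O)cc3)cnc2N)cn1`: 12.5 ug/mL

Compound 2 stands with the higher of the two numbers in this assay, but the step from a 2.0-fold higher number from compound 1 to compound 2 (0.30 log units; within the scatter) is within the scatter, so compound 1 and compound 2 cannot be separated on these data.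

Compound 3, `COc1ccc(-c2cc(-c3ccc(C(=O)N(C)C)cc3)cnc2N)cn1`, has not yet been measured. It differs from compound 2 by dimethylamino in place of amino on a carbonyl carbon, that is, carbamoyl to dimethylcarbamoyl.

Going by the values given here, only one measured step exists, and it changes the same position of the same core, from a triazolyl to a carbamoyl group; it stayed within the scatter. Among the compounds with values here, no measured step adds or removes methyl groups on an amide nitrogen, so nothing speaks directly for or against a change here. On that basis the step from compound 2 to compound 3 is expected to be small: a 1.3-fold lower number from compound 2 to compound 3 (0.10 log units; within the scatter), none beyond the scatter. Compound 3 is estimated at 10 ug/mL, in the range 4 ug/mL to 25 ug/mL.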

Compound 3, solubility: > 100 ug/mL
Compound 3: a limit, no number; the forecaster's own chance of this, stated with the estimate: 5%; at least 10-fold (1.00 log units) between middle value and limit.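

Compound 3 stands as a limit, not a number, in this assay: the limit of > 100 ug/mL in this assay, at which 1 of the 3 values shown sits.

Going by these compounds alone, with dimethylamino in place of amino on a carbonyl carbon, the series shows its first step beyond the scatter, an at least 8.0-fold higher number from compound 2 to compound 3 (0.90 log units; beyond the scatter), whereas the only earlier step stayed within it. Dimethylcarbamoyl in place of 1H-1,2,4-triazol-1-yl on an aromatic carbon reads an at least 15-fold higher number from compound 1 to compound 3 (1.20 log units; beyond the scatter), so the read-out at this position does not stay flat across the groups shown, although both steps end at a limit and their full size cannot be read.

The compounds shown leave open whether the step goes with the loss of the hydrogen-bond donor counted on amino or with the added carbons. A methylamino group on the same carbonyl carbon would separate the two, and a longer chain such as diethylamino or a cyclic amine such as pyrrolidine would test how far the step extends.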